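Extending the Chain One Carbon Further

The source may report more compounds than this note shows. Statements on the series, on what has been measured and on what is new or still open speak of the compounds shown alone.

Three compounds have been measured in a functional assay on the whole organism with Canis familiaris (Canis lupus familiaris) as the target, at a dose of 8 mg/kg by the oral route; on this read-out lower numbers stand for a weaker effect and higher numbers for a stronger effect at the one dose given:
compound 1 `Cc1nc2c(OCc3ccccc3)cccn2c1N` — 96%
compound 2 `Nc1cnc2c(OCc3ccccc3)cccn12` — 43%
compound 3 `CCc1nc2c(OCc3ccccc3)cccn2c1N` — 59%

Compound 3 stands second highest of the three in this assay; the nearest step to it is a number 16 percentage points higher from compound 2 to compound 3 (beyond the scatter) and the furthest is a number 37 percentage points lower from compound 1 to compound 3 (beyond the scatter). Compound 4 `CCCc1nc2c(OCc3ccccc3)cccn2c1N` differs from compound 3 by methyl in place of hydrogen on a saturated chain carbon, two bonds along the chain from an aromatic carbon. The measured step that bears on this change is the one from methyl to ethyl, a number 37 percentage points lower from compound 1 to compound 3 (beyond the scatter), a large drop, and the present change is the same difference cut one bond further out. Compound 4 is therefore expected to fall again in this assay, by a number 14 percentage points lower from compound 3 to compound 4 (beyond the scatter), though probably less steeply than before. Compound 4 is estimated at 45%, within a range of 22% to 70%.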

Compound 4, a percentage reported as inhibition, in the whole organism at one dose (the size of the read-out at that dose, not a potency): 0%
Estimate against measurement, compound 4: 45 percentage points above; measured number outside the range, below it.
By their numbers in this assay, from the lowest: compound 4; then compound 2; then compound 3; then compound 1.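

In this assay the effect does not level off as the chain grows at this position: going from ethyl to propyl costs more (a number 59 percentage points lower from compound 3 to compound 4 (beyond the scatter)) than going from methyl to ethyl (a number 37 percentage points lower from compound 1 to compound 3 (beyond the scatter)). Propyl also takes the compound below the one with hydrogen on the aromatic carbon (a number 43 percentage points lower from compound 2 to compound 4 (beyond the scatter)), whereas ethyl stayed above it, and the whole series from methyl spans a wide drop (a number 96 percentage points lower from compound 1 to compound 4 (beyond the scatter)). No evidence is available to explain this loss.

Going by these compounds, whether a branched isopropyl group, a cyclopropyl ring or a methoxymethyl chain at this carbon would behave like methyl or like propyl remains open. So does the response of these compounds at other doses.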